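Compound 1 to Compound 4: A Smaller Ring on the Same Core

The source may report more compounds than this note shows. Statements on the series, on what has been measured and on what is new or still open speak of the compounds shown alone.

Measured compounds in an assay on isolated protein for inhibition of Leucine-rich repeat serine/threonine-protein kinase 2 variant G2019S (Homo sapiens), read by TR-FRET and LanthaScreen, with stated times of 50 min and 30 min, in the presence of a further agent that is not named here; on this read-out higher numbers stand for weaker inhibition and lower numbers for stronger inhibition:
Compound 1 `Cc1nn(CC2(O)COC2)cc1Nc1nc(N)c2c(C#N)c(N3CCC[C@H]3C)n(C)c2n1` gives 51 nM.
Compound 2 `C[C@@H]1CCCN1c1c(C#N)c2c(N)nccc2n1C` gives 28 nM.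
Compound 3 `C[C@H]1CCCN1c1c(C#N)c2c(N)ncnc2n1C` gives 3080 nM.

Among these three numbers compound 1 stands second highest. Its nearest neighbour is compound 2, whose number lies within the usual scatter of it, so the two cannot be told apart. Compound 3 lies far beyond the scatter, with a much higher number than compound 1.

Compound 4 `Cc1nn(C2COC2)cc1Nc1nc(N)c2c(C#N)c(N3CCC[C@H]3C)n(C)c2n1` has not yet been measured in this assay. It differs from compound 1 in one place: oxetan-3-yl in place of (3-hydroxyoxetan-3-yl)methyl on an aromatic nitrogen. Among the measured compounds shown here, no measured pair shows the effect of this change, so the direction is uncertain. Because compound 1 sits at 51 nM and the change is small, compound 4 is expected to land close by, with a step of a 1.2-fold higher number from compound 1 to compound 4 (0.07 log units; within the scatter) that stays within the scatter. The estimate for compound 4 is 60 nM, in the range 25 nM to 150 nM.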

Compound 4, half-maximal inhibitory concentration: 25 nM
Compound 4: middle estimate off by 2.4-fold (0.38 log units), on the high side; measured number inside the range.
By their numbers in this assay, from the lowest: compounds 4, 2 and 1 (each within the scatter of the next, the first and the last beyond it); then compound 3.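

In this assay, among the compounds shown here, this is the first measured change on the aromatic nitrogen of the five-membered ring: oxetan-3-yl in place of (3-hydroxyoxetan-3-yl)methyl gives a 2.0-fold lower number from compound 1 to compound 4 (0.31 log units; beyond the scatter), a modest step. Inhibition therefore does not depend on the larger group or its hydrogen-bond donor, since compound 4 has no donor in this group and still gives the lower number. Nothing measured here accounts for the step.

The compounds shown leave open how a plain methyl, a 2-hydroxyethyl chain or an amine such as azetidin-3-yl would compare with oxetan-3-yl on this nitrogen.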